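Compound 3 to compound 4: one ring exchanged

This account rests on a few compounds, and the source may have more. Where it says the series, first, only, none or still open, it means among the compounds named here.

In a physicochemical assay for metabolic stability, read by HPLC and mass spectrometry, in phosphate buffer, at 37 degrees C, at pH 7.4 (a higher number here means that the compound lasts longer, a lower number that the compound disappears faster), compound 3 `C[C@@H]1CN(C[C@@H]2[C@H](NC(=O)/C(=N\OC(C)(C)C(=O)O)c3csc(N)n3)C(=O)N2S(=O)(=O)O)C(=O)O1` gives > 37 h, which is only a limit. Compound 1 `CC(C)(O/N=C(\C(=O)N[C@@H]1C(=O)N(S(=O)(=O)O)[C@@H]1CN1CCC1=O)c1csc(N)n1)C(=O)O` gives > 1000 h, also a limit. Compound 2 `CC(C)(O/N=C(\C(=O)N[C@@H]1C(=O)N(S(=O)(=O)O)[C@@H]1Cn1cnnc1)c1csc(N)n1)C(=O)O`, carrying 4H-1,2,4-triazol-4-yl, gives a true number of 113 h.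

Compound 4 `CC(C)(O/N=C(\C(=O)N[C@@H]1C(=O)N(S(=O)(=O)O)[C@@H]1Cn1cc(CO)nn1)c1csc(N)n1)C(=O)O` brings this change: 4-(hydroxymethyl)-1H-1,2,3-triazol-1-yl in place of 5-methyl-2-oxo-1,3-oxazolidin-3-yl on a saturated chain carbon bound to a saturated ring carbon. For the measured compounds named here, the only readable step so far is an at least 8.8-fold lower number from compound 1 to compound 2 (0.94 log units; beyond the scatter). It shows that the group on this saturated chain carbon can matter. Compound 2, at 113 h, is the nearest guide, since it also holds a triazole there, so a similar half-life is expected. With only a limit as the starting point, the direction stays uncertain. The estimated change is a step that the limit leaves unreadable from compound 3 to compound 4. For compound 4 the expected half-life is 100 h, with an estimated range from 35 h to 300 h.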

Compound 4, half-life: > 37 h
Compound 4 ended at the assay's limit; the forecaster's own chance of this, stated with the estimate: 25%; the middle value is on the limit's open side.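

In this assay, for the compounds shown here, compound 4 gives > 37 h, which is only a limit, so no step to compound 4 from compound 1, compound 2 or compound 3 can be read. The compounds shown leave open how long compound 3 and compound 4 truly last.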